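Two Potent Antagonists and a Biaryl Variant Not Yet Tested

This account rests on a few compounds, and the source may have more. Where it says the series, first, only, none or still open, it means among the compounds named here.

Compound 2 `CC(C(=O)NCc1ccc(C(F)(F)F)cc1OCc1ccccc1)c1ccc(NS(C)(=O)=O)c(F)c1`: 0.9 nM
Compound 1 `CC(C(=O)NCc1ccc(C(F)(F)F)cc1N1CCC(Cc2ccccc2)CC1)c1ccc(NS(C)(=O)=O)c(F)c1`: 1.4 nM

In an assay on CHO cells for antagonist activity at transient receptor potential cation channel subfamily V member 1 (Homo sapiens), read by FLIPR (a lower number here means a stronger inhibitor, a higher number a weaker inhibitor), compound 2 gives 0.9 nM, the lowest of the two numbers, and compound 1 gives 1.4 nM, a gap within the scatter. Compound 3 `COc1cc(OC)cc(-c2cc(C(F)(F)F)ccc2CNC(=O)C(C)c2ccc(NS(C)(=O)=O)c(F)c2)c1` differs from compound 2 by 3,5-dimethoxyphenyl in place of benzyloxy on an aromatic carbon, on an aromatic carbon ortho to a large group and meta to a trifluoromethyl group. Among the measured compounds shown here, no measured pair shows such a step, so its size is unknown. Compound 3 is estimated at 3 nM, between 0.8 nM and 12 nM, which would mean a step of a 3.3-fold higher number from compound 2 to compound 3 (0.52 log units; beyond the scatter), expected slightly weaker but possibly within the scatter.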

Compound 3, inhibition constant: 5.8 nM
Estimate against measurement, compound 3: 1.9-fold (0.29 log units) below, within the range that was stated.
By their numbers in this assay, from the lowest: compounds 2 and 1 (each within the scatter of the next); then compound 3.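

In this assay this aromatic carbon, ortho to a large group and meta to a trifluoromethyl group, proves sensitive to what it carries: 3,5-dimethoxyphenyl in place of benzyloxy gives a 6.4-fold higher number from compound 2 to compound 3 (0.81 log units; beyond the scatter) and so the first step read here. The earlier compounds shown here offered no such step, and this one shows that not every large group at this carbon is equivalent. Whether the methoxy groups or the phenyl ring itself accounts for the step stays open, and a plain phenyl or a 3-methoxyphenyl at this carbon would separate the two. Nothing available bears on the reason for this result.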